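The source may hold more compounds than are shown below. What is called first, only, known or untested is meant among the compounds shown, and "the series" means these compounds.

Three compounds have been measured in a functional assay on HepG2 cells (Homo sapiens) for inhibition, read by MTT assay, with a stated time of 72 h; a higher number here means a weaker inhibitor, a lower number a stronger inhibitor:

Compound 1 `Cc1ccc(NC(=O)C2CCN(C/C=C/c3ccccc3)CC2)cc1`: 33900 nM
Compound 2 `COc1ccc(NC(=O)C2CCN(C/C=C/c3ccccc3)CC2)cc1`: 88800 nM
Compound 3 `O=C(Nc1cccc(Br)c1)C1CCN(C/C=C/c2ccccc2)CC1`: 19200 nM

On these numbers, compound 3 cannot be separated from one neighbour, a 1.8-fold lower number from compound 1 to compound 3 (0.25 log units; within the scatter), but it stands clear of the other, a 4.6-fold lower number from compound 2 to compound 3 (0.67 log units; beyond the scatter). Compound 4 `O=C(Nc1nccs1)C1CCN(C/C=C/c2ccccc2)CC1` carries 1,3-thiazol-2-yl in place of 3-bromophenyl on an amide-type nitrogen. The two steps above bear on this change, since each replaces the group on that nitrogen, and even the larger was only modest. Neither brings in a five-membered ring, so the data give only a loose guide. A modest rise is expected, a 2.1-fold higher number from compound 3 to compound 4 (0.32 log units; beyond the scatter). The estimate for compound 4 is 40000 nM, with an expected range of 15000 nM to 100000 nM.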

Compound 4, half-maximal inhibitory concentration: 22400 nM
The estimate for compound 4 lay 1.8-fold (0.25 log units) above the measured number; the range from low to high includes it.
By their numbers in this assay, from the lowest: compounds 3, 4 and 1 (each within the scatter of the next); then compound 2.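

Swapping the six-membered carbon ring of 3-bromophenyl for the five-membered 1,3-thiazol-2-yl on the amide-type nitrogen gives a 1.2-fold higher number from compound 3 to compound 4 (0.07 log units; within the scatter), so this ring change leaves the two compounds inseparable. The 4-methylphenyl group cannot be separated from it either, a 1.5-fold lower number from compound 1 to compound 4 (0.18 log units; within the scatter), whereas the 4-methoxyphenyl group stands apart, a 4.0-fold lower number from compound 2 to compound 4 (0.60 log units; beyond the scatter). No measurement available here accounts for this. From the compounds shown here alone, it remains open whether a pyridine ring or a butyl chain on that nitrogen would fall within the same range, and whether any group there could lower the number much further.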